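Amide substituent change on a cyclobutyl triazole series

The compounds below may be only part of what the source reports. "The series", "measured", "known", "first", "only" and "open" are said of these compounds alone.

Measured compounds:
Compound 1, `Cn1c(-c2ccccc2)nnc1C1(c2ccc(Cl)cc2)CCC1`, 29%
Compound 2, `CCNC(=O)c1ccc(-c2nnc(C3(c4ccc(Cl)cc4)CCC3)n2C)cc1`, 71%

Compound 1 carries hydrogen on an aromatic carbon, whereas compound 2 carries ethylcarbamoyl there. In a functional assay on the whole organism (strain ICR) for inhibition, with Mus musculus as the target, read by scintillation counting, with a stated time of 4 h, at a dose of 10 mg/kg by the oral route (a lower number here means less inhibition, a higher number more inhibition at the dose given (going by the name of the read-out)), compound 1 gives 29% and compound 2 gives 71%, so the step is a number 42 percentage points higher from compound 1 to compound 2 (beyond the scatter). Among the measured compounds shown here, compound 2 thus stands as the higher of the two measured values in this assay, and compound 1 is its only neighbour.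

Compound 3, `Cn1c(-c2ccc(C(=O)NC(C)(C)C)cc2)nnc1C1(c2ccc(Cl)cc2)CCC1`, differs from compound 2 by tert-butyl in place of ethyl on an amide-type nitrogen. For the measured compounds named here, the one measured step concerns placing ethylcarbamoyl where hydrogen stood; no measured step alters the alkyl on the amide-type nitrogen itself. The expectation therefore rests on compound 2 alone, and the estimated step is a number 6 percentage points lower from compound 2 to compound 3 (within the scatter), no change beyond the scatter. Compound 3 is estimated at 65% in this assay, within a range of 40% to 85%.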

Compound 3, a percentage reported as inhibition, in the whole organism at one dose (the size of the read-out at that dose, not a potency): 71%
Beside the measured number, compound 3's estimate is 6 percentage points below it, within the range that was stated.
By their numbers in this assay, from the lowest: compound 1; then compounds 2 and 3 (each within the scatter of the next).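

In this assay, replacing ethyl with tert-butyl on the amide-type nitrogen gives no change at the digits printed from compound 2 to compound 3 (within the scatter), so going from 2 to 4 carbons in this alkyl group leaves the read-out within the scatter. The large gain over hydrogen on the aromatic carbon is also not confined to ethylcarbamoyl: (tert-butyl)carbamoyl gives a number 42 percentage points higher from compound 1 to compound 3 (beyond the scatter). No evidence is available that would explain either result.

The compounds shown leave open whether the alkyl group on the amide-type nitrogen is needed at all, and how a plain carbamoyl or a carboxylic acid in the same place would compare. Since each number comes from a single dose, they also leave open whether compound 2 and compound 3 match in potency.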